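Swapping fluoro for methylsulfanyl on compound 2

The compounds below may be only part of what the source reports. "The series", "measured", "known", "first", "only" and "open" are said of these compounds alone.

In a physicochemical assay for lipophilicity (on this read-out lower numbers stand for lower lipophilicity and higher numbers for higher lipophilicity), compound 2 `Fc1ccccc1C1=NC(c2ccccc2)CO1` reads 3.51 and sits within the scatter of compound 3 `Fc1cccc(Cl)c1C1=NC(c2ccccc2)CO1` at 3.45 on this scale. Compound 1 `Ic1ccccc1-c1ncco1` at 2.3 lies beyond the scatter under compound 2 on the same scale.

Compound 4 `CSc1ccccc1C1=NC(c2ccccc2)CO1` has not yet been measured. It differs from compound 2 by methylsulfanyl in place of fluoro on an aromatic carbon in a single place: methylsulfanyl in place of fluoro on an aromatic carbon, ortho to a large group. For the measured compounds named here, the one measured step that bears on this is a number 0.06 log units lower from compound 2 to compound 3 (within the scatter) with chloro in place of hydrogen on an aromatic carbon. That step stayed within the scatter, but it is a different swap and guides only loosely. Going by the values given here, no measured step removes fluoro or brings in methylsulfanyl. From the structural change alone, a modest rise in this assay is expected, and the estimated size is a number 0.34 log units higher from compound 2 to compound 4 (beyond the scatter) with a wide margin. For compound 4 the estimated value is 3.85 with a range from 3.45 to 4.25 on this scale.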

Compound 4, partition coefficient: 3.5
Compound 4: the middle estimate sits 0.35 log units above what was measured, within the range that was stated.
By their numbers in this assay, from the lowest: compound 1; then compounds 3, 4 and 2 (each within the scatter of the next).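

In this assay, replacing fluoro with methylsulfanyl on an aromatic carbon, ortho to a large group, gives a number 0.01 log units lower from compound 2 to compound 4 (within the scatter) and so leaves the two compounds indistinguishable on this scale. The earlier step showed only chloro entering in place of hydrogen, whereas this one shows that the fluoro itself can give way to a group with a carbon and a sulfur without a change that stands out from the scatter. Nothing available explains why the read-out stays put.

On these data alone, whether the same holds for an amine, a carboxylic acid or a longer chain such as ethylsulfanyl at this place remains open. Also open, as far as these compounds go, is whether methylsulfanyl would give a similar result with the chloro of compound 3 present.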